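Acyl chain shortening in the nucleoside ester series

The source may report more compounds than this note shows. Statements on the series, on what has been measured and on what is new or still open speak of the compounds shown alone.

Compound 1 `Cc1cn([C@H]2CO[C@@H](COC(=O)C3CCCCC3)O2)c(=O)[nH]c1=O` carries a cyclohexanecarbonyl ester on the shared core; compound 2 `CCCCCCCCCCCCCCCC(=O)OC[C@@H]1OC[C@H](n2cc(C)c(=O)[nH]c2=O)O1` carries a palmitoyl ester on the same core. In an ADME assay on Vero cells (Chlorocebus sabaeus) for cytotoxicity, read by MTT assay, with a stated time of 3 days (a lower number here means a stronger inhibitor, a higher number a weaker inhibitor), compound 2 gives 92200 nM, the only plain number shown for the series. For compound 1 this assay reports only a limit, > 100000 nM. Of the two values, (the limit of > 100000 nM in this assay, at which 1 of the 2 values shown sits).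

Compound 3 `CCCCCCCC(=O)OC[C@@H]1OC[C@H](n2cc(C)c(=O)[nH]c2=O)O1` is not yet measured. It differs from compound 2 by hydrogen in place of octyl on a saturated chain carbon, seven bonds along the chain from a carbonyl carbon, in words: hydrogen in place of octyl on a saturated chain carbon, seven bonds along the chain from a carbonyl carbon. Among the compounds with values here, no step between measured compounds is available to anchor this change. The expected step in this assay is a 1.6-fold higher number from compound 2 to compound 3 (0.21 log units; within the scatter), small and, if anything, toward a weaker inhibitor. Compound 3 is estimated at 150000 nM, within 60000 nM to 400000 nM, with a fair chance that this assay returns only a limit.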

Compound 3, half-maximal inhibitory concentration: > 100000 nM
Compound 3: a limit, no number; the forecaster's own chance of this, stated with the estimate: 60%; the middle value is on the limit's open side.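

Hydrogen in place of octyl, on a saturated chain carbon, seven bonds along the chain from a carbonyl carbon, gives in this assay an at least 1.0-fold higher number from compound 2 to compound 3 (0.03 log units; that floor lies within the scatter); this is only a floor, so shortening the chain shows no step that can be claimed beyond the scatter. Compound 3 returns a limit and not a number, and the step joining it to compound 1 links two limits and cannot be read. The series in this assay now reads mostly as limits: the limit of > 100000 nM in this assay, at which 2 of the 3 values shown sit.

Still open, as far as these compounds go, is how far past its limit compound 3 actually lies, which leaves the true size of the chain-shortening step unknown. Also open, from the compounds shown here alone, is whether an acyl chain of intermediate length, or an amine or a carboxylic acid at the chain end, would return a plain number in this assay.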